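A few compounds are considered here, and "the series" means these few. Any claim that something is new, unique, unknown or untested is made for them only; others in the source may bear on it.

Compound 1, `CC(C)=CCOc1cc(Nc2nccc(C)n2)ccc1Cl`: in a functional assay on MT2 cells (Homo sapiens) for cytotoxicity (a higher number here means that more compound is tolerated, a lower number that less compound is tolerated), compound 1 gives < 200 nM, which is a limit of the assay and not a number.
Compound 2, `COc1ccnc(Nc2ccc(Cl)c(OCC=C(C)C)c2)n1`: in this assay compound 2 gives 9000 nM.
Compound 3, `CC(C)=CCOc1cc(Nc2nccc(C(F)(F)F)n2)ccc1Cl`: in this assay compound 3 gives 2500 nM.

Compound 1 stands at the bottom of the three: its result is the limit of < 200 nM in this assay, at which 1 of the 3 values shown sits, so it is the least tolerated of the set, and only a limit is known for it. Both measured steps away from compound 1 raise the number sharply: an at least 45-fold higher number from compound 1 to compound 2 (1.65 log units; beyond the scatter), and an at least 12-fold higher number from compound 1 to compound 3 (1.09 log units; beyond the scatter). Between the two altered compounds, a 3.6-fold lower number from compound 2 to compound 3 (0.56 log units; beyond the scatter).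

Compound 4, `CC(C)=CCOc1cc(Nc2nccs2)ccc1Cl`, is not yet measured. It differs from compound 1 as follows: 1,3-thiazol-2-yl in place of 4-methylpyrimidin-2-yl on a nitrogen on an aromatic ring. For the measured compounds named here, no measured step exchanges the whole 4-methylpyrimidin-2-yl ring; the two measured steps only alter the group on that ring, and both of them were large and upward. Going by the values given here, that is the only guidance the data give, and it bears on compound 4 indirectly, since a change at the same place moved the number strongly in both measured cases.

On that basis compound 4 is expected to be tolerated better than compound 1, with an at least 5.0-fold higher number from compound 1 to compound 4 (0.69 log units; beyond the scatter). The estimate for compound 4 in this assay is 1000 nM, within a range from 150 nM to 7000 nM, with the lower end still near the limit at which compound 1 sits.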

Compound 4, half-maximal cytotoxic concentration: 26000 nM
Compound 4: the middle estimate sits 26-fold (1.41 log units) below what was measured, and the stated range ends below it.
By their numbers in this assay, from the lowest: compound 3; then compound 2; then compound 4. At a limit, below all of these: compound 1.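

The earlier compounds shown here altered only the group on the 4-methylpyrimidin-2-yl ring, whereas compound 4 shows that the whole ring on this nitrogen can be exchanged for 1,3-thiazol-2-yl, with an at least 130-fold higher number from compound 1 to compound 4 (2.11 log units; beyond the scatter) in this assay. The result for compound 1 is a limit and not a number: the limit of < 200 nM in this assay, at which 1 of the 4 values shown sits. The exchange also takes the number past those of the ring-substituted compounds, with compound 4 at 26000 nM, compound 2 at 9000 nM and compound 3 at 2500 nM, even though the counts of hydrogen-bond donors and acceptors are the same in the group that leaves and the group that enters.

The compounds shown leave open whether the rise belongs to the five-membered ring, to the sulfur or to the loss of the methyl, and a 1,3-thiazol-2-yl ring carrying a methyl group or a plain pyrimidin-2-yl ring would help to separate these. Also open, on these data alone, is how an amine or a carboxylic acid on the 1,3-thiazol-2-yl ring would move the number in this assay.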